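Compound 4: one methoxy and one trifluoromethyl group

This account rests on a few compounds, and the source may have more. Where it says the series, first, only, none or still open, it means among the compounds named here.

Compound 1 `CN(c1cccc2c1CN(c1nc(Nc3cc(C(F)(F)F)cc(C(F)(F)F)c3)ncc1C(F)(F)F)C2)S(C)(=O)=O` gives > 30000 nM (a limit)
Compound 2 `COc1cc(Nc2ncc(C(F)(F)F)c(N3Cc4cccc(N(C)S(C)(=O)=O)c4C3)n2)cc(OC)c1` gives 630 nM
Compound 3 `Cc1cc(C)cc(Nc2ncc(C(F)(F)F)c(N3Cc4cccc(N(C)S(C)(=O)=O)c4C3)n2)c1` gives > 30000 nM (a limit)

All three were tested in a functional assay on OVCAR-3 cells (Homo sapiens) for antiproliferative activity, read by spectrophotometry, with a stated time of 2 days (a lower number here means a stronger inhibitor of growth, a higher number a weaker inhibitor of growth), and compound 3 stands at the limit of > 30000 nM in this assay, at which 2 of the 3 values shown sit, rather than at a true number. Compound 4 `COc1cc(Nc2ncc(C(F)(F)F)c(N3Cc4cccc(N(C)S(C)(=O)=O)c4C3)n2)cc(C(F)(F)F)c1` differs from it as follows: 3-methoxy-5-(trifluoromethyl)phenyl in place of 3,5-dimethylphenyl on a nitrogen on an aromatic ring that is, 3-methoxy-5-(trifluoromethyl)phenyl in place of 3,5-dimethylphenyl on a nitrogen on an aromatic ring.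

The step that bears most directly is an at least 47-fold higher number from compound 2 to compound 3 (1.67 log units; beyond the scatter) and it is large. It suggests that a methoxy group may recover activity, and compound 4 keeps one. Compound 1 carries trifluoromethyl groups on that ring and gives > 30000 nM as a limit. The expected result is therefore partial recovery, with a lower number and stronger inhibition of growth, though not as far as compound 2. In this assay compound 2 gives 630 nM. The estimated change is an at least 6.0-fold lower number from compound 3 to compound 4 (0.77 log units; beyond the scatter) and it remains uncertain, since its starting point is only a limit. For compound 4 the estimated value is 5000 nM with an expected range from 800 nM to 30000 nM.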

Compound 4, concentration for 50% growth inhibition: > 30000 nM
Compound 4 ended at the assay's limit; the forecaster's own chance of this, stated with the estimate: 35%; middle value at least 6.0-fold (0.77 log units) away from the limit.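

Compound 4 gives > 30000 nM in this assay, and this is a limit. Trifluoromethyl in place of one methoxy gives an at least 47-fold higher number from compound 2 to compound 4 (1.67 log units; beyond the scatter), so in this set one methoxy on the ring does not hold activity when the other substituent is trifluoromethyl, and only compound 2, with its 3,5-dimethoxyphenyl group, gives a true number. The steps joining compound 4 to compound 3 and to compound 1 cannot be read because both ends of each are limits: the limit of > 30000 nM in this assay, at which 3 of the 4 values shown sit.

From the compounds shown here alone, whether the activity of compound 2 depends on both methoxy groups stays open, since a partner such as a hydroxyl, an ethoxy or an amine could still serve alongside one methoxy. Going by these compounds, how compound 1, compound 3 and compound 4 truly rank against one another also remains unknown.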